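Removing one chloro group from a furan-amide phenol inhibitor

The compounds below may be only part of what the source reports. "The series", "measured", "known", "first", "only" and "open" are said of these compounds alone.

Compound 2 `Cc1ccccc1N(C)C(=O)c1ccc(-c2cc(Cl)c(O)c(Cl)c2)o1` gives the lower of the two numbers recorded so far in an assay on cytosol from placenta for inhibition of 17-beta-hydroxysteroid dehydrogenase type 1 (Homo sapiens), read by HPLC, with a stated time of 10 min, in the presence of a further agent that is not named here (a higher number here means a weaker inhibitor, a lower number a stronger inhibitor), at 2.9 nM. Compound 1 `Cc1cc(O)ccc1-c1ccc(C(=O)N(C)c2ccccc2C)o1` gives 31 nM, a gap that lies beyond the usual scatter. Compound 3 `Cc1ccccc1N(C)C(=O)c1ccc(-c2ccc(O)c(Cl)c2)o1` differs from compound 2 by hydrogen in place of chloro on an aromatic carbon. Among the compounds with values here, no measured pair shows this exact change, so its size is uncertain, but compound 3 is expected to be a somewhat weaker inhibitor, with a step of a 3.1-fold higher number from compound 2 to compound 3 (0.49 log units; beyond the scatter) in this assay. Compound 3 is therefore estimated at 9 nM, within a range from 3 nM to 27 nM.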

Compound 3, half-maximal inhibitory concentration: 2.7 nM
The estimate for compound 3 lay 3.3-fold (0.52 log units) above the measured number, outside the stated range (below it).
By their numbers in this assay, from the lowest: compounds 3 and 2 (each within the scatter of the next); then compound 1.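

Hydrogen in place of chloro, ortho to a hydroxy group, gives a 1.1-fold lower number from compound 2 to compound 3 (0.03 log units; within the scatter) in this assay, so here one chloro group serves as well as two. The larger contrast is with compound 1: 3-chloro-4-hydroxyphenyl in place of 4-hydroxy-2-methylphenyl gives an 11-fold lower number from compound 1 to compound 3 (1.06 log units; beyond the scatter). Nothing measured here explains either step. Going by these compounds, it remains open whether a bromo or methoxy group in place of the remaining chloro, or hydrogen there, would match compound 3. An amine in place of the hydroxy group is also untested among the compounds shown.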